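A few compounds are considered here, and "the series" means these few. Any claim that something is new, unique, unknown or untested is made for them only; others in the source may bear on it.

Compound 1 (`COc1cc(F)ccc1N1C(=O)CSC1c1cccc(C(=O)NCCCCc2ccccc2)c1`) gives 71.1 nM
Compound 2 (`O=C(NCCCCc1ccccc1)c1cccc(C2SCC(=O)N2c2ccccn2)c1`) gives 19.7 nM

In a functional assay on HOS-TE85 cells (Homo sapiens) for inhibition, read by CCK-8 assay, with a stated time of 72 h (a lower number here means a stronger inhibitor, a higher number a weaker inhibitor), compound 2 has the lower of the two numbers. Compound 3 (`O=C(NCCCCc1ccccc1)c1cccc(C2SCC(=O)N2c2cccc(F)c2)c1`) differs from it at one place (3-fluorophenyl in place of pyridin-2-yl on an amide-type nitrogen in a ring), with 3-fluorophenyl in place of pyridin-2-yl on an amide-type nitrogen in a ring. Among the compounds with values here, one measured step bears on this: the modest change at that nitrogen from 4-fluoro-2-methoxyphenyl to pyridin-2-yl (a 3.6-fold lower number from compound 1 to compound 2 (0.56 log units; beyond the scatter)). Compound 3 again carries a carbon-only aromatic ring there, so a smaller move to a higher number is expected in this assay (a 2.1-fold higher number from compound 2 to compound 3 (0.33 log units; beyond the scatter)). For compound 3 the estimate is 42 nM (expected range 14 nM to 120 nM).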

Compound 3, half-maximal inhibitory concentration: 32.4 nM
Compound 3: the middle estimate sits 1.3-fold (0.11 log units) above what was measured; the range from low to high includes it.
By their numbers in this assay, from the lowest: compounds 2 and 3 (each within the scatter of the next); then compound 1.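

In this assay, the ring nitrogen of pyridin-2-yl is not needed on this amide-type nitrogen: replacing that ring with 3-fluorophenyl gives a 1.6-fold higher number from compound 2 to compound 3 (0.22 log units; within the scatter). The carbon-only ring is therefore tolerated here, and the substituents on it count, with a 2.2-fold lower number from compound 1 to compound 3 (0.34 log units; beyond the scatter). Nothing measured on hand accounts for either step.

Open, as far as these compounds go, is how an aromatic ring bearing an amine or a carboxylic acid would read on this nitrogen. Also open, from the compounds shown here alone, is whether the fluorine and the methoxy of 4-fluoro-2-methoxyphenyl would read differently apart.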